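The source may hold more compounds than are shown below. What is called first, only, known or untested is meant among the compounds shown, and "the series" means these compounds.

Compound 1, `O=C(O[C@H]1C[C@H](n2cc(F)c(=O)[nH]c2=O)O[C@@H]1COP(=O)(O)Oc1cccnc1)c1ccccc1`, is one of two measured members of this small set. In a functional assay on T98G cells (Homo sapiens) for cytotoxicity, read by MTT assay, with a stated time of 48 h (a lower number here means a stronger inhibitor, a higher number a weaker inhibitor), compound 1 gives 1300 nM. For the measured compounds named here, its only neighbour, compound 2, `O=C(O[C@H]1C[C@H](n2cc(F)c(=O)[nH]c2=O)O[C@@H]1COP(=O)(O)Oc1ccc2ncccc2c1)c1ccccc1`, gives 1300 nM in this assay, and the step of no change at the digits printed from compound 1 to compound 2 (within the scatter) shows that swapping one aromatic group for another on the same oxygen left the value where it was. Compound 1 therefore stands level with compound 2, within the scatter.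

Compound 3, `C[N+]1(C)CCC(OP(=O)([O-])OC[C@H]2O[C@@H](n3cc(F)c(=O)[nH]c3=O)C[C@@H]2OC(=O)c2ccccc2)CC1`, has not yet been measured. It differs from compound 1 in this way: a group of 12 heavy atoms (7 carbon, 1 nitrogen, 3 oxygen, 1 phosphorus; one six-membered non-aromatic ring with 1 hetero atom) in place of a group of 10 heavy atoms (5 carbon, 1 nitrogen, 3 oxygen, 1 phosphorus; one six-membered aromatic ring with 1 hetero atom), on an oxygen on a saturated carbon. Going by the values given here, the one measured step, from compound 1 to compound 2, bears on the same position but kept an aromatic ring, whereas compound 3 brings in a non-aromatic one; no measured step covers that kind of exchange. Among the compounds with values here, with only one step, and that one flat, the expectation for compound 3 is a step of about no change at the digits printed from compound 1 to compound 3 (within the scatter) in this assay, meaning no movement beyond the scatter, though the range is kept broad. Compound 3 is thus estimated at 1300 nM, with a likely span from 500 nM to 3500 nM.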

Compound 3, half-maximal inhibitory concentration: 6700 nM
Compound 3: the middle estimate sits 5.2-fold (0.71 log units) below what was measured, outside the stated range (above it).
By their numbers in this assay, from the lowest: compounds 1 and 2 (each within the scatter of the next); then compound 3.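

In this assay, the group on this oxygen proves able to move the number, which the earlier pair of aromatic groups did not show: no change at the digits printed from compound 1 to compound 2 (within the scatter). Replacing the group with one six-membered aromatic ring by the larger group with one six-membered non-aromatic ring gives a 5.2-fold higher number from compound 1 to compound 3 (0.71 log units; beyond the scatter). This exchange changes the ring type, the group's size and its count of hydrogen-bond donors all at once, so this single step cannot assign the rise to any one of them, and nothing shown here explains it.

From the compounds shown here alone, whether a cyclohexyl group or a phenyl group on this oxygen would sit nearer compound 1 or compound 3 remains open. So does whether the same step would appear in a cell line other than T98G.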